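The source may hold more compounds than are shown below. What is called first, only, known or untested is meant among the compounds shown, and "the series" means these compounds.

Compound 1 `O=C(NCc1cc(Cl)ccc1-n1cnnn1)[C@@H]1CCNN1C(=O)[C@H](O)c1ccccc1` is reported in an ADME assay on liver for metabolic stability, with Liver microsome (Homo sapiens) as the target, read by LC-MS, using microsomes (a higher number here means faster removal of the compound, a lower number slower removal), with < 16 mL.min-1.g-1 as a limit of the assay and not as a number. Compound 2 `O=C(NCc1cc(Cl)ccc1-n1cnnn1)[C@@H]1[C@H]2C[C@H]2CN1C(=O)[C@H](O)c1ccccc1` gives 61 mL.min-1.g-1 in this assay and compound 3 `CC(C)(C)C[C@@H](O)C(=O)N1[C@@H]2C[C@@H]2C[C@H]1C(=O)NCc1cc(Cl)ccc1-n1cnnn1` gives 71 mL.min-1.g-1 in the same read-out, so these two numbers lie within the usual scatter of each other.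

Compound 4 `O=C(NCc1cc(Cl)ccc1-n1cnnn1)[C@@H]1[C@H]2C[C@H]2CN1C(=O)[C@H](O)C1CCCCC1` keeps the core of compound 2 and differs from it by cyclohexyl in place of phenyl on a saturated chain carbon bound to a carbonyl carbon and an oxygen on a saturated carbon in one place. It has cyclohexyl in place of phenyl on a saturated chain carbon bound to a carbonyl carbon and an oxygen on a saturated carbon. One six-membered aromatic ring of carbon only thus gives way to one six-membered non-aromatic ring of carbon only.

Going by the values given here, no measured pair shows this change on its own. Where compound 2 has phenyl, compound 3 carries a saturated carbon group on a core that is not identical, and compound 3 reads 71 mL.min-1.g-1 in this assay with no sign of a large shift. A small rise is therefore expected, and the estimated 1.4-fold higher number from compound 2 to compound 4 (0.14 log units; within the scatter) stays within the scatter. The estimated value for compound 4 is 85 mL.min-1.g-1 with an expected range from 40 mL.min-1.g-1 to 170 mL.min-1.g-1 in this read-out.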

Compound 4, intrinsic clearance in microsomes: 110 mL.min-1.g-1
The estimate for compound 4 lay 1.3-fold (0.11 log units) below the measured number; the range from low to high includes it.
By their numbers in this assay, from the lowest: compounds 2, 3 and 4 (each within the scatter of the next). At a limit, below all of these: compound 1.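

In this assay, the step at this position, on a saturated chain carbon bound to a carbonyl carbon and an oxygen on a saturated carbon, is a 1.8-fold higher number from compound 2 to compound 4 (0.26 log units; within the scatter) when cyclohexyl stands in place of phenyl. Going by these compounds alone, this gives the first direct reading of the change on a single core: one six-membered aromatic ring of carbon only gives way to one six-membered non-aromatic ring of carbon only, and the two compounds cannot be told apart in this read-out. Nothing in the data shown bears on a cause for this step.

As far as these compounds go, it remains open whether a ring carrying nitrogen, such as pyridyl or piperidinyl, or an open chain such as isobutyl would read differently at this place on the same core, and whether cyclohexyl would read the same on another core. From the compounds shown here alone, compound 1 gives < 16 mL.min-1.g-1, which is a limit of the assay and not a number, and it differs from the other compounds in more than one place, so what its core would do with cyclohexyl also stays open.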